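A few compounds are considered here, and "the series" means these few. Any claim that something is new, unique, unknown or untested is made for them only; others in the source may bear on it.

Measured in an ADME assay on HUVEC cells (Homo sapiens) for cytotoxicity, read by MTT assay, with a stated time of 24 h; a lower number here means that less compound is tolerated, a higher number that more compound is tolerated:

- compound 1 `Brc1cccc(/C=C/c2nnc(-c3ccc4c(c3)OCCO4)o2)c1`: 322000 nM
- compound 2 `O=[N+]([O-])c1ccc(/C=C/c2nnc(-c3ccc4c(c3)OCCO4)o2)cc1`: 299000 nM

Compound 2, at 299000 nM, stands within the usual scatter of compound 1, at 322000 nM, so the two numbers cannot be told apart. The next compound to be tested is compound 3 `Fc1ccc(/C=C/c2nnc(-c3ccc4c(c3)OCCO4)o2)cc1`. It carries fluoro in place of nitro on an aromatic carbon, para to a large group (fluoro in place of nitro on an aromatic carbon). Going by the values given here, no measured pair shows a change in one place only, so the data give no direct size for this swap. Among the compounds with values here, the two values so far lie close together, and no step beyond the scatter is expected in this assay. The expected change is a 1.0-fold higher number from compound 2 to compound 3 (0.00 log units; within the scatter), which would stay within the scatter. For compound 3 the estimated value is 300000 nM, with an expected range from 150000 nM to 600000 nM.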

Compound 3, half-maximal cytotoxic concentration: 325000 nM
Beside the measured number, compound 3's estimate is 1.1-fold (0.03 log units) below it; the measured number falls inside the stated range.
By their numbers in this assay, from the lowest: compounds 2, 1 and 3 (each within the scatter of the next).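

In this assay, fluoro in place of nitro on an aromatic carbon, para to a large group, gives a 1.1-fold higher number from compound 2 to compound 3 (0.04 log units; within the scatter). Going by these compounds alone, this is the first direct measure of the swap, and it shows that the two groups cannot be told apart at this position. Replacing 3-bromophenyl with 4-fluorophenyl gives a 1.0-fold higher number from compound 1 to compound 3 (0.00 log units; within the scatter), so this change also stays inside the scatter, and no information shown here explains these results.

Going by these compounds, it remains open whether an amine, a carboxylic acid or a longer chain on that aromatic carbon would give a step beyond the scatter. On these data alone, compounds 1, 2 and 3 also share one core, so the effect of changing that core on the number in this assay is unknown.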